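The compounds below may be only part of what the source reports. "The series", "measured", "known", "first", "only" and "open" are said of these compounds alone.

Compound 1 `C=CCC(O/N=C(\C)C(=O)O)c1ccc(OCc2ccc3ccccc3n2)cc1`: 142 nM
Compound 2 `C/C(=N\OC(c1ccc(OCc2ccc3ccccc3n2)cc1)C1CCCC1)C(=O)O`: 16 nM
Compound 3 `O=C(O)/C=N/OC(c1ccc(OCc2ccc3ccccc3n2)cc1)C1CCCCCC1`: 18 nM

In a functional assay for inhibition of Polyunsaturated fatty acid 5-lipoxygenase (Homo sapiens) (a lower number here means a stronger inhibitor, a higher number a weaker inhibitor), compound 3 gives 18 nM, the second highest of the three numbers; compound 2, at 16 nM, lies within the scatter of it, while compound 1, at 142 nM, lies beyond the scatter on the higher side. Compound 4 `C/C(=N\OC(c1ccc(OCc2ccc3ccccc3n2)cc1)C1CCCCCC1)C(=O)O` differs from compound 3 by a group of 6 heavy atoms (3 carbon, 1 nitrogen, 2 oxygen; no ring) in place of a group of 5 heavy atoms (2 carbon, 1 nitrogen, 2 oxygen; no ring), on an oxygen on a saturated carbon. For the measured compounds named here, no measured step shows this change; the only measured step, an 8.9-fold lower number from compound 1 to compound 2 (0.95 log units; beyond the scatter), alters the ring-bearing group and does not bear on it. Compound 2 and compound 3, which carry the two groups that differ here together with different rings, give numbers within the scatter of each other. Compound 4 is therefore expected to show a 1.3-fold lower number from compound 3 to compound 4 (0.11 log units; within the scatter), nothing beyond the scatter. The estimate for compound 4 is 14 nM, ranging from 5 nM to 40 nM.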

Compound 4, half-maximal inhibitory concentration: 13 nM
Beside the measured number, compound 4's estimate is 1.1-fold (0.03 log units) above it; the range from low to high includes it.
By their numbers in this assay, from the lowest: compounds 4, 2 and 3 (each within the scatter of the next); then compound 1.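

In this assay the group of 6 heavy atoms in place of the group of 5 heavy atoms, on an oxygen on a saturated carbon, gives a 1.4-fold lower number from compound 3 to compound 4 (0.14 log units; within the scatter) with cycloheptyl held constant, so this exchange leaves the number within the scatter. Cycloheptyl in place of cyclopentyl likewise gives a 1.2-fold lower number from compound 2 to compound 4 (0.09 log units; within the scatter) with that group held constant. Cycloheptyl in place of allyl gives an 11-fold lower number from compound 1 to compound 4 (1.04 log units; beyond the scatter) and so extends the large gain seen with cyclopentyl to a second ring.

Nothing measured explains these numbers. As far as these compounds go, whether an amide in place of the carboxylic acid, or a cyclopropyl ring on the saturated carbon, would hold these numbers remains open.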